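Swapping Methoxy for Nitro: Expected Growth Inhibition

The source may report more compounds than this note shows. Statements on the series, on what has been measured and on what is new or still open speak of the compounds shown alone.

Compound 1, `Cc1cc2c(C(C)C)ccc(C)c2cc1OC(=O)c1cccc(C(F)(F)F)c1`: "not active" (no number reported)
Compound 2, `COc1ccc(C(=O)Oc2cc3c(C)ccc(C(C)C)c3cc2C)cc1`: 88.6%

Of the compounds shown here, two have been tested in a functional assay on K562 cells (Homo sapiens) for antiproliferative activity, read by sulforhodamine B assay, with a stated time of 48 h, tested at 50 uM; on this read-out lower numbers stand for less inhibition and higher numbers for more inhibition at the one concentration tested (going by the name of the read-out). For the measured compounds named here, compound 1 was reported as "not active" (no number reported) without any number, while compound 2 gives 88.6%, the only figure available, so compound 2 stands alone as the single compound with a measured degree of inhibition. Compound 3 has the structure `Cc1cc2c(C(C)C)ccc(C)c2cc1OC(=O)c1ccc([N+](=O)[O-])cc1`. It differs from compound 2 in one place: nitro in place of methoxy on an aromatic carbon. Going by the values given here, no pair of measured compounds differing in one place exists, so the size of such a step cannot be read from earlier numbers. Compound 1, which carries a different group on that ring, was reported as "not active" (no number reported) without a number, which suggests that the group on this ring can change the reported outcome in this assay; a downward step in this assay beyond the scatter therefore seems more likely than none. Compound 3 is expected to give 50%, with a range from 10% to 85%. This corresponds to an expected step of a number 38.6 percentage points lower from compound 2 to compound 3 (beyond the scatter).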

Compound 3, a percentage reported as inhibition, at one concentration (the size of the read-out at that concentration, not a potency): 100%
The estimate for compound 3 lay 50 percentage points below the measured number; the whole stated range lies below it.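

In this assay, nitro in place of methoxy on the aromatic carbon para to a large group gives a number 11.4 percentage points higher from compound 2 to compound 3 (beyond the scatter). For the compounds shown here, this is the first measured step at this place, and it shows that the position can carry nitro as well as methoxy with no loss of inhibition, with compound 3 reaching 100% at the one concentration tested. Nothing measured here bears on why the reading rises with this change.

As far as these compounds go, what an amine or a carboxylic acid on this same carbon would do remains open. Also open, from the compounds shown here alone, is how far compound 2 and compound 3 differ in potency, as a reading at a single concentration gives the size of the effect there and not a potency.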